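The source may hold more compounds than are shown below. What is called first, only, known or untested is meant among the compounds shown, and "the series" means these compounds.

In a functional assay on HepG2 cells (Homo sapiens) for cytotoxicity, read by crystal violet staining, with a stated time of 72 h (a lower number here means a stronger inhibitor, a higher number a weaker inhibitor), the measured compounds are:
compound 1 `COc1cc(/C=C/C(=O)/C=C(O)/C=C/c2ccc(O[C@H]3C=C(C)[C@@H](O)C[C@@H]3[C@@H](C)CCC=C(C)C)c(OC)c2)ccc1O`, 25000 nM;
compound 2 `COc1cc(/C=C/C(=O)/C=C(O)/C=C/c2ccc(O[C@H]3C=C(C)[C@@H](O)C[C@@H]3[C@@H](C)CC(=O)C=C(C)C)c(OC)c2)ccc1O`, 15400 nM;
compound 3 `COc1cc(/C=C/C(O)=C/C(=O)/C=C/c2ccc(O)cc2)ccc1O[C@H]1C=C(C)[C@@H](O)C[C@@H]1[C@@H](C)CC(=O)C=C(C)C`, 13000 nM.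

Compound 3 does not stand apart from the other two in this assay: the step of a 1.2-fold lower number from compound 2 to compound 3 (0.07 log units; within the scatter) is within the scatter, and its gap to compound 1 is also within the scatter. Compound 4 `CC(C)=CC(=O)C[C@H](C)[C@H]1C[C@H](O)C(C)=C[C@@H]1Oc1ccc(/C=C/C(O)=C/C(=O)/C=C/c2ccc(O)cc2)cc1` differs from compound 3 by hydrogen in place of methoxy on an aromatic carbon. Of the measured steps, only a 1.2-fold lower number from compound 2 to compound 3 (0.07 log units; within the scatter) concerns the same kind of change, and it stayed within the scatter; the step of a 1.6-fold lower number from compound 1 to compound 2 (0.21 log units; within the scatter) concerns a different change and was also within the scatter. In this assay compound 4 is therefore expected to show no step beyond the scatter, a 1.1-fold lower number from compound 3 to compound 4 (0.03 log units; within the scatter), with an estimated value of 12000 nM and a range of 5000 nM to 30000 nM.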

Compound 4, half-maximal inhibitory concentration: 22700 nM
Compound 4: the middle estimate sits 1.9-fold (0.28 log units) below what was measured, and the stated range covers the measured number.
By their numbers in this assay, from the lowest: compounds 3, 2, 4 and 1 (each within the scatter of the next).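

In this assay, replacing methoxy with hydrogen on the aromatic carbon ortho to a large group and meta to a large group gives a 1.7-fold higher number from compound 3 to compound 4 (0.24 log units; within the scatter). This position therefore tolerates the loss of methoxy within the scatter, and compound 4, which carries no methoxy on either aromatic ring, shows that this holds even when the last methoxy goes. No measurement shown here explains the result. The compounds shown leave open whether an amine or a longer ether chain such as ethoxy on this aromatic carbon would shift the number beyond the scatter.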